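Benzylthio chlorine shifted on a dihydropyrimidine carboxanilide

This account rests on a few compounds, and the source may have more. Where it says the series, first, only, none or still open, it means among the compounds named here.

Compound 1, `CC1=C(C(=O)Nc2ccc([N+](=O)[O-])cc2)C(c2ccc(Br)cc2)N=C(SCc2ccc(Cl)cc2)N1`, in a functional assay on the whole organism (artery, strain albino) with Rattus norvegicus as the target, with a stated time of 900 min, at a dose of 10 mg/kg by the oral route (on this read-out higher numbers stand for more inhibition at the one dose given (going by the name of the read-out) and lower numbers for less inhibition), gives 19%.
Compound 2, `CC1=C(C(=O)Nc2ccc([N+](=O)[O-])cc2)C(c2cccc([N+](=O)[O-])c2)N=C(SCc2cccc(Cl)c2)N1`, in this assay gives 10.8%.

Among the measured compounds shown here, compound 2 stands beside compound 1 on these two numbers, its value within the usual scatter of compound 1, and no single-change step between them can be read from the pair. Compound 3, `CC1=C(C(=O)Nc2ccc([N+](=O)[O-])cc2)C(c2cccc([N+](=O)[O-])c2)N=C(SCc2ccc(Cl)cc2)N1`, differs from compound 2 only at one place: 4-chlorophenyl in place of 3-chlorophenyl on a saturated chain carbon bound to a sulfur. For the measured compounds named here, no measured step isolates this change, so the expected step from compound 2 to compound 3 in this assay is a number 3.2 percentage points higher from compound 2 to compound 3 (within the scatter), not beyond the scatter. Compound 3 is thus estimated at 14%, in a range from 3% to 27%.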

Compound 3, a percentage reported as inhibition, in the whole organism at one dose (the size of the read-out at that dose, not a potency): 12.3%
The estimate for compound 3 lay 1.7 percentage points above the measured number, and the stated range covers the measured number.
By their numbers in this assay, from the lowest: compounds 2, 3 and 1 (each within the scatter of the next).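

In this assay, among the compounds shown here, the swap of 3-chlorophenyl for 4-chlorophenyl on a saturated chain carbon bound to a sulfur gives a number 1.5 percentage points higher from compound 2 to compound 3 (within the scatter) and so supplies the first measured step at this position. The change of 4-bromophenyl to 3-nitrophenyl on a saturated ring carbon gives a number 6.7 percentage points lower from compound 1 to compound 3 (within the scatter) and adds a second step that stays inside the usual variation. Nothing measured here bears on why either step has its size.

Still open, on these data alone, is whether any group at the chain position moves the read-out beyond the scatter, for instance an unsubstituted phenyl or a carboxylic acid in place of the chlorophenyl.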